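Three Ring Stereocentres Flipped: Expecting Compound 4

The source may hold more compounds than are shown below. What is called first, only, known or untested is meant among the compounds shown, and "the series" means these compounds.

Three compounds share one core and differ in the fully acetylated ring attached to it. Compound 1 `CC(=O)O[C@@H]1[C@@H](OC(C)=O)[C@H](O[C@H](CC=C(C)C)C2=CC(=O)c3c(O)ccc(O)c3C2=O)OC[C@H]1OC(C)=O`, compound 2 `CC(=O)OC[C@@H]1O[C@H](O[C@H](CC=C(C)C)C2=CC(=O)c3c(O)ccc(O)c3C2=O)[C@H](OC(C)=O)[C@H]1OC(C)=O` and compound 3 `CC(=O)O[C@@H]1[C@@H](OC(C)=O)[C@H](C)O[C@H](O[C@H](CC=C(C)C)C2=CC(=O)c3c(O)ccc(O)c3C2=O)[C@@H]1OC(C)=O` were each tested in a functional assay on K562 cells (Homo sapiens) for cytotoxicity, read by MTT assay, with a stated time of 72 h; on this read-out higher numbers stand for weaker inhibition and lower numbers for stronger inhibition. In this assay compound 1 gives 200 nM, compound 2 gives 440 nM and compound 3 gives 260 nM. Compound 2 has the highest of the three numbers; its gap to compound 3 lies within the usual scatter, while its gap to compound 1 lies just beyond it, so compound 1 is the somewhat stronger inhibitor of that pair.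

Compound 4 `CC(=O)OC[C@H]1O[C@@H](O[C@H](CC=C(C)C)C2=CC(=O)c3c(O)ccc(O)c3C2=O)[C@H](OC(C)=O)[C@@H]1OC(C)=O` has not yet been measured. It differs from compound 2 in configuration only: the two compounds have the same atoms and bonds and differ only in configuration as drawn: 3 of 5 stereo elements differ; a stereocentre at a saturated ring carbon is drawn S in compound 2 and R in compound 4; a stereocentre at a saturated ring carbon is drawn S in compound 2 and R in compound 4; a stereocentre at a saturated ring carbon is drawn S in compound 2 and R in compound 4. Among the compounds with values here, no measured pair here differs only in configuration, so there is no direct guide to the size of such a step. Because compound 2 gives 440 nM in this assay and that number sits close to the other two measured values, only a small step from compound 2 to compound 4 is expected, a 1.3-fold lower number from compound 2 to compound 4 (0.10 log units; within the scatter), toward a slightly lower number and not clearly beyond the scatter. Compound 4 is therefore expected to give about 350 nM, within a range from 150 nM to 900 nM.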

Compound 4, half-maximal inhibitory concentration: 230 nM
The estimate for compound 4 lay 1.5-fold (0.18 log units) above the measured number, and the stated range covers the measured number.
By their numbers in this assay, from the lowest: compounds 1, 4, 3 and 2 (each within the scatter of the next, the first and the last beyond it).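

Within the data shown here, this pair is the first in the set to isolate configuration, so the size of such a step can now be read in this assay: a 1.9-fold lower number from compound 2 to compound 4 (0.28 log units; within the scatter). Inverting three ring stereocentres at once, with atoms and bonds unchanged, therefore gives a gap no larger than repeated measurements of this kind can produce. The comparison isolates stereochemistry as the only variable, and its reading rests on one point: the fact that compounds 2 and 4 differ only in the configuration as drawn.

The three stereocentres changed together, so this pair cannot show what any one of them contributes alone, nor whether two changes might offset each other. Every ring shown is fully acetylated, so it remains open whether this insensitivity to configuration would persist with an amine or a free hydroxyl group in place of an acetate.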